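The source may hold more compounds than are shown below. What is called first, only, known or untested is meant among the compounds shown, and "the series" means these compounds.

Measured compounds:
- compound 1, `Cc1cc(O)cc(-c2nn(CC#N)cc2-c2ccnc(-c3ccc(Oc4ccccc4)cc3)c2)c1`, in a functional assay on SN12C cells (Homo sapiens) for inhibition, read by sulforhodamine B assay, with a stated time of 48 h (on this read-out lower numbers stand for stronger inhibition of growth and higher numbers for weaker inhibition of growth), compound 1 gives 4020 nM
- compound 2, `COc1cc(C)cc(-c2nn(CC#N)cc2-c2ccnc(-c3ccc(N(C)C)cc3)c2)c1`, in this assay compound 2 gives 33100 nM

Within the data shown here, compound 2 stands at the highest of the two numbers measured so far; compound 1 sits at the lower number, and the gap between the two is beyond the scatter. The two compounds differ in more than one place, so no single-step reading of that gap is available: one can only note that the phenol-bearing, phenoxy-bearing compound 1 shows the lower number.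

Compound 3, `Cc1cc(O)cc(-c2nn(CC#N)cc2-c2ccnc(-c3ccc(N(C)C)cc3)c2)c1`, is the next compound in line. Relative to compound 2 the change is hydrogen in place of methyl on an oxygen on an aromatic ring. Compound 3 thus keeps the dimethylamino-bearing side of compound 2 while taking over the hydroxy of compound 1.

Among the measured compounds shown here, no measured pair isolates this change. Given that compound 1, the only compound carrying the hydroxy, gives 4020 nM, a step toward lower numbers is expected for compound 3 in this assay, of moderate size and with wide uncertainty. The expected step is a 2.5-fold lower number from compound 2 to compound 3 (0.41 log units; beyond the scatter). Compound 3 is accordingly estimated at 13000 nM, within 4000 nM to 40000 nM.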

Compound 3, concentration for total growth inhibition: 30000 nM
For compound 3 the middle estimate is 2.3-fold (0.36 log units) below the measured one; the measured number falls inside the stated range.
By their numbers in this assay, from the lowest: compound 1; then compounds 3 and 2 (each within the scatter of the next).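

In this assay, methoxy to hydroxy on the 3-methoxy-5-methylphenyl group gives a 1.1-fold lower number from compound 2 to compound 3 (0.04 log units; within the scatter), so with dimethylamino in the series this exchange of methyl for hydrogen on the oxygen does not separate the two compounds. The gap seen earlier between two compounds differing in more than one place now has a single-step reading: with the hydroxy held in common, dimethylamino in place of phenoxy on an aromatic carbon gives a 7.5-fold higher number from compound 1 to compound 3 (0.87 log units; beyond the scatter) and the step stands beyond the scatter, while the hydroxy itself does not account for the lower number of compound 1 in the dimethylamino setting. No accompanying measurement bears on either step, and neither can be explained from what is at hand.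

Among these compounds, whether methoxy to hydroxy is equally silent in the presence of phenoxy remains open, since the one step for this exchange rests on dimethylamino alone. Also open, from the compounds shown here alone, is how groups such as benzyloxy or a primary amine would read in place of phenoxy on that aromatic carbon, and so whether the step from phenoxy to dimethylamino reflects something particular to either group.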